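The compounds below may be only part of what the source reports. "The series", "measured", "known", "first", "only" and "open" are said of these compounds alone.

Compound 2 `CN(C)C(=O)c1cc2cnc(Nc3ccc(C(=O)NCCCCN=C=S)cc3)nc2n1C1CCCC1` in a functional assay on A549 cells (Homo sapiens) for inhibition, read by CCK-8 assay, with a stated time of 72 h, tested at 10 uM (a lower number here means a weaker effect, a higher number a stronger effect of the compound at the concentration tested), gives 102%. Compound 1 `CN(C)C(=O)c1cc2cnc(Nc3ccc(S(=O)(=O)NCCCCCN=C=S)cc3)nc2n1C1CCCC1` gives 102%, and the step of no change at the digits printed from compound 1 to compound 2 (within the scatter). Compound 3 `CN(C)C(=O)c1cc2cnc(Nc3ccc(C(=O)NCCCCN=C=S)cc3F)nc2n1C1CCCC1` gives 24.4%, the step being a number 77.6 percentage points lower from compound 2 to compound 3 (beyond the scatter). Compound 2 thus stands level with compound 1, the two together the highest of the three numbers, and far from compound 3.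

Compound 4 `CN(C)C(=O)c1cc2cnc(Nc3ccc(NC(=O)CCCCN=C=S)cc3)nc2n1C1CCCC1` differs from compound 2 by a group of 10 heavy atoms (6 carbon, 2 nitrogen, 1 oxygen, 1 sulfur; no ring) in place of a group of 10 heavy atoms (6 carbon, 2 nitrogen, 1 oxygen, 1 sulfur; no ring), on an aromatic carbon. The step that bears on this is no change at the digits printed from compound 1 to compound 2 (within the scatter), an exchange of the group on the same aromatic carbon with the core kept; the step of a number 77.6 percentage points lower from compound 2 to compound 3 (beyond the scatter) concerns fluoro on the ring and is of another kind. A step of a number 5 percentage points lower from compound 2 to compound 4 (within the scatter) is therefore expected, none beyond the scatter. Compound 4 is estimated at 97% in this assay, between 70% and 105%.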

Compound 4, a percentage reported as inhibition, at one concentration (the size of the read-out at that concentration, not a potency): 102%
Beside the measured number, compound 4's estimate is 5 percentage points below it; measured number inside the range.
By their numbers in this assay, from the lowest: compound 3; then compounds 1, 2 and 4 (each within the scatter of the next).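

Working notes: in this assay the group para to a large group keeps its atoms but joins them differently, and the result is no change at the digits printed from compound 2 to compound 4 (within the scatter); against the sulfonamide-bearing chain of compound 1 the result is no change at the digits printed from compound 1 to compound 4 (within the scatter). Compound 1, compound 2 and compound 4 therefore cannot be separated by this read-out at one concentration. No available evidence explains this tolerance.

Potency across lower concentrations remains open for these three compounds. Also open, going by these compounds, is whether activity survives an amine in place of the isothiocyanate, or a longer chain.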